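A few compounds are considered here, and "the series" means these few. Any claim that something is new, unique, unknown or untested is made for them only; others in the source may bear on it.

In an ADME assay on microsomes (Rattus norvegicus) for metabolic stability (on this read-out lower numbers stand for a shorter-lived compound and higher numbers for a longer-lived compound), compound 2 (`CC(C)(CO)C(=O)N1N=CCC1c1ccccc1`) stands higher of the two numbers at 0.917 h and compound 1 (`O=C(C1CCCC1)N1N=CCC1c1ccccc1`) sits lower at 0.2 h on the same read-out. Compound 3 (`O=C(C1CCOCC1)N1N=CCC1c1ccccc1`) is still unmeasured: it has oxan-4-yl in place of 1-(hydroxymethyl)-1-methylethyl on a carbonyl carbon. For the measured compounds named here, the one measured step that bears on this (a 4.6-fold higher number from compound 1 to compound 2 (0.66 log units; beyond the scatter)) is modest but beyond the scatter, and it put 1-(hydroxymethyl)-1-methylethyl in place of cyclopentyl on that carbonyl carbon. Oxan-4-yl keeps a ring, as compound 1 at 0.2 h does in its cyclopentyl, and an oxygen, as compound 2 at 0.917 h does in its side group. A fall in this assay is therefore expected, smaller than that measured step. The expected step (a 2.3-fold lower number from compound 2 to compound 3 (0.36 log units; beyond the scatter)) lies just beyond the scatter. For compound 3 the estimate is 0.4 h with an expected range from 0.15 h to 1 h on this read-out.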

Compound 3, half-life: > 1.5 h
Compound 3: no number, only a limit (the forecaster's own chance of this, stated with the estimate: 2%); middle value at least 3.7-fold (0.57 log units) from the limit.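

In this assay compound 3 gives > 1.5 h and that is a limit of the assay, not a number: the limit of > 1.5 h in this assay, at which 1 of the 3 values shown sits.
With oxan-4-yl in place of cyclopentyl on the carbonyl carbon the series shows an at least 7.5-fold higher number from compound 1 to compound 3 (0.87 log units; beyond the scatter) and so a ring at this position is compatible with a longer half-life, and the hydrogen-bond donor of 1-(hydroxymethyl)-1-methylethyl is not required for such a rise. Against that open-chain group the change gives an at least 1.6-fold higher number from compound 2 to compound 3 (0.21 log units; that floor lies within the scatter) and, with that floor within the scatter, the two oxygen-bearing groups cannot yet be placed in order.

From the compounds shown here alone, the true half-life of compound 3, and with it the full size of both steps, stays open. Also open, going by these compounds, is whether the rise depends on the oxygen in the ring or would hold for an amine such as piperidin-4-yl at the same carbonyl carbon.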